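Reading a Benzyl Swap Without a Measured Step

The source may report more compounds than this note shows. Statements on the series, on what has been measured and on what is new or still open speak of the compounds shown alone.

Measured so far in a functional assay on MCF7 cells (Homo sapiens) for cytotoxicity, read by MTT assay, with a stated time of 72 h; on this read-out higher numbers stand for weaker inhibition and lower numbers for stronger inhibition
- compound 1 `N[C@H]1CC[C@H](Nc2c(C(=O)NCc3ccc(Oc4ccccc4)cc3)nc(Br)c3cccnc23)CC1` gives 7900 nM
- compound 2 `COc1cccc(CNC(=O)c2nc(Br)c3cccnc3c2N[C@H]2CC[C@H](N)CC2)c1` gives "not determined" (no result reported)
- compound 3 `COc1ccc(CNC(=O)c2nc(Br)c3cccnc3c2N[C@H]2CC[C@H](N)CC2)cc1` gives "not determined" (no result reported)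

Compound 3 has no place on this scale, since the entry for compound 3 reads "not determined" (no result reported) and no single number stands behind it. The same gap applies to compound 2, so only compound 1 supplies a number. Going by the values given here, still unmeasured is compound 4 `N[C@H]1CC[C@H](Nc2c(C(=O)NCc3cccc(C(F)(F)F)c3)nc(Br)c3cccnc23)CC1` with its one structural change. That change runs 3-(trifluoromethyl)phenyl in place of 4-methoxyphenyl on a saturated chain carbon bound to an amide-type nitrogen and puts 3-(trifluoromethyl)phenyl in place of 4-methoxyphenyl on a saturated chain carbon bound to an amide-type nitrogen.

Among the compounds with values here, no measured pair shows how far such a swap can move results in this assay, so no step beyond the scatter is expected and no direction can be named. Within the data shown here, the sole reference is compound 1 at 7900 nM with the same shared core, and the expectation rests on that number. For compound 4 the estimated value is 7000 nM with an expected range from 2500 nM to 20000 nM around it.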

Compound 4, half-maximal inhibitory concentration: 15000 nM
Beside the measured number, compound 4's estimate is 2.1-fold (0.33 log units) below it; the range from low to high includes it.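

In this assay compound 3 has no single number, and no new step can be read from compound 3 and compound 4. How the swap from 4-methoxybenzyl to 3-(trifluoromethyl)benzyl moves the result stays open, and no evidence shown bears on the result.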